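Adding a Second Chloro to the Benzyl Ring

The compounds below may be only part of what the source reports. "The series", "measured", "known", "first", "only" and "open" are said of these compounds alone.

Measured so far:
compound 1 `O=C(O)c1ccc(C(=O)/C(=C\c2ccc(Br)c([N+](=O)[O-])c2)SCc2ccccc2Cl)cc1`: 1000 nM
compound 2 `Cc1ccc(S(=O)(=O)/C(=C/c2c[nH]c3ccc(Cl)cc23)C(=O)c2ccc(Br)cc2)cc1`: 10000 nM
compound 3 `O=C(O)c1ccc(C(=O)/C(=C\c2ccc(F)c([N+](=O)[O-])c2)SCc2ccccc2Cl)cc1`: 1000 nM

In a functional assay on DU-145 cells (Homo sapiens) for inhibition, read by trypan blue exclusion, with a stated time of 96 h (on this read-out higher numbers stand for weaker inhibition of growth and lower numbers for stronger inhibition of growth), compound 1 gives 1000 nM, level with compound 3 and together with it the lowest of the three numbers; compound 2 stands at 10000 nM, a higher number beyond the scatter. Compound 4 `O=C(O)c1ccc(C(=O)/C(=C\c2ccc(Br)c([N+](=O)[O-])c2)SCc2ccc(Cl)cc2Cl)cc1` differs from compound 1 by chloro in place of hydrogen on an aromatic carbon. Within the data shown here, the only measured step, no change at the digits printed from compound 1 to compound 3 (within the scatter), concerns a halogen swap on another ring and so says little about adding a chloro here; no measured pair shows that change. With nothing pointing either way, the step is expected to stay within the scatter, no change at the digits printed from compound 1 to compound 4 (within the scatter). Compound 4 is therefore estimated at 1000 nM, between 400 nM and 2500 nM.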

Compound 4, concentration for 50% growth inhibition: 1000 nM
Estimate against measurement, compound 4: no gap at the digits printed; low and high end bracket the measured number.
By their numbers in this assay, from the lowest: compounds 1, 3 and 4 (each within the scatter of the next); then compound 2.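

In this assay the 2-chlorobenzyl group can become 2,4-dichlorobenzyl with the step reading no change at the digits printed from compound 1 to compound 4 (within the scatter) and so this aromatic carbon accepts chloro in place of hydrogen without a change in growth inhibition beyond the scatter. The earlier fluoro and bromo pair concerned a different ring and could not show this. No measurement at hand explains why the number holds here.

The compounds shown leave open whether a group other than chloro on this carbon, such as a methoxy group, an amine or a longer chain, would shift the number in either direction.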